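The source may report more compounds than this note shows. Statements on the series, on what has been measured and on what is new or still open speak of the compounds shown alone.

Measured compounds:
compound 1 `CO[C@H]1CC=C2CCN(C)[C@H]2C1`: 30000 nM
compound 2 `COCCO[C@H]1CC=C2CCN(C)[C@H]2C1`; for compound 2 the value > 300000 nM is a limit of the assay, not a number.

Among the measured compounds shown here, in an assay on HEK293 cells for antagonist activity at Nicotinic acetylcholine receptor alpha-4/beta-2 (Mus musculus), read by FLIPR, using a membrane potential dye (a higher number here means a weaker inhibitor, a lower number a stronger inhibitor), compound 1 gives 30000 nM, the only number in the set; the other entry sits at the limit of > 300000 nM in this assay, at which 1 of the 2 values shown sits. For the measured compounds named here, the one measured step, an at least 10-fold higher number from compound 1 to compound 2 (1.00 log units; beyond the scatter), concerns the ether substituent and not the ring nitrogen, so it does not bear on the change considered here. Compound 3 `CO[C@H]1CC=C2CCN[C@H]2C1` differs from compound 1 by hydrogen in place of methyl on an amine nitrogen in a ring. Going by the values given here, with no comparable step measured, no shift beyond the scatter is expected in this assay. For compound 3 the estimate is 30000 nM, range 10000 nM to 100000 nM, an expected step of no change at the digits printed from compound 1 to compound 3 (within the scatter).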

Compound 3, half-maximal inhibitory concentration: 100000 nM
Compound 3: the middle estimate sits 3.3-fold (0.52 log units) below what was measured, within the range that was stated.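

In this assay the ring nitrogen proves to be a position that responds, with a 3.3-fold higher number from compound 1 to compound 3 (0.52 log units; beyond the scatter) when hydrogen replaces methyl. A change at this amine nitrogen in a ring therefore moves the read-out, not only a change at the ether substituent, and the methyl-bearing compound 1 is the stronger inhibitor of this pair. Nothing given here accounts for this step.

From the compounds shown here alone, whether an ethyl group, a benzyl group or a longer chain on this nitrogen would improve on methyl stays open. So does how hydrogen on this nitrogen would behave alongside the longer ether of compound 2.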